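Oxirane in Place of Nitrile on a Shared Core

A few compounds are considered here, and "the series" means these few. Any claim that something is new, unique, unknown or untested is made for them only; others in the source may bear on it.

Three measured compounds share one core and differ only in a single group on the aromatic ring. Compound 1 `O=C1C=CC(=O)N1c1cc(C(F)(F)F)cc(C(F)(F)F)c1` in an ADME assay for pharmacokinetics, read by LC-MS, in phosphate buffer, with a stated time of 72 h, at pH 7.4, tested at 250 uM (a lower number here means that the compound disappears faster, a higher number that the compound lasts longer), gives < 0.017 h, which is a limit of the assay and not a number (the limit of < 0.017 h in this assay, at which 1 of the 3 values shown sits). Compound 2 `C#Cc1cc(C(F)(F)F)cc(C(F)(F)F)c1` in this assay gives 1.6 h. Compound 3 `N#Cc1cc(C(F)(F)F)cc(C(F)(F)F)c1` in this assay gives > 50 h, again a limit of the assay rather than a number (the limit of > 50 h in this assay, at which 1 of the 3 values shown sits). So the number for compound 3 is known only as a limit, the highest point the assay reports. The steps that end at compound 3 were both large: an at least 31-fold higher number from compound 2 to compound 3 (1.49 log units; beyond the scatter) and an at least 2900-fold higher number from compound 1 to compound 3 (3.46 log units; beyond the scatter). Compound 4 `FC(F)(F)c1cc(C2CO2)cc(C(F)(F)F)c1` carries the next change: oxiran-2-yl in place of cyano on an aromatic carbon. Within the data shown here, no measured step exchanges the nitrile for a small ring of this kind, so the expectation rests only on the fact that every change at this position moved the number strongly. The change is expected to lower the number, as an at least 3.3-fold lower number from compound 3 to compound 4 (0.52 log units; beyond the scatter), with wide uncertainty. The estimate for compound 4 is 15 h, between 2 h and 60 h.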

Compound 4, half-life: > 50 h
Compound 4 ended at the assay's limit; the forecaster's own chance of this, stated with the estimate: 30%; middle value at least 3.3-fold (0.52 log units) away from the limit.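

The oxiran-2-yl group joins the nitrile at the top of what this assay can report, so a reading at this limit on the shared core is not tied to the nitrile alone: the limit of > 50 h in this assay, at which 2 of the 4 values shown sit.

Against the other two groups the change is large, with an at least 31-fold higher number from compound 2 to compound 4 (1.49 log units; beyond the scatter) and an at least 2900-fold higher number from compound 1 to compound 4 (3.46 log units; beyond the scatter). The step between compound 3 and compound 4 cannot be read, so neither of these two groups can be placed ahead of the other.

Going by these compounds, how long either compound really lasts remains open, since each result is a limit and not a number. Also open, on these data alone, is whether a cyclopropyl ring, an amine or a carboxylic acid at this position would stay at the limit or fall towards compound 2.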